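Adding a pyrazole to the indane imidazoline core

The source may report more compounds than this note shows. Statements on the series, on what has been measured and on what is new or still open speak of the compounds shown alone.

compound 1 `Cc1c(OCC2=NCCN2)ccc(Cl)c1NS(C)(=O)=O` — in a functional assay on CHO cells for agonist activity at Alpha-1D adrenergic receptor (Homo sapiens), read by FLIPR and calcium flux (on this read-out higher numbers stand for an effect only at larger amounts of compound and lower numbers for an effect already at smaller amounts), compound 1 gives > 10000 nM, a limit of the assay.
compound 2 `c1ccc2c(c1)CCC2c1ncc[nH]1` — in this assay compound 2 gives > 10000 nM, a limit of the assay.
compound 3 `COc1c(Cl)ccc2c1CCC2c1ncc[nH]1` — in this assay compound 3 gives > 10000 nM, a limit of the assay.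

Compound 2 thus stands at the limit of > 10000 nM in this assay, at which 3 of the 3 values shown sit, and no number among the three allows any ranking. Compound 4 `c1cc(-c2cn[nH]c2)c2c(c1)C(c1ncc[nH]1)CC2` differs from compound 2 by 1H-pyrazol-4-yl in place of hydrogen on an aromatic carbon. Going by the values given here, no step between measured compounds is available, so the size of this change is open. Because compound 2 sits at > 10000 nM as a limit, compound 4 is expected to stay without a measurable effect. The step that the limit leaves unreadable from compound 2 to compound 4 is expected to be none beyond the scatter. Compound 4 is estimated at 15000 nM, between 3000 nM and 50000 nM, most likely reported again only as a limit.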

Compound 4, half-maximal effective concentration: 319 nM
Beside the measured number, compound 4's estimate is 47-fold (1.67 log units) above it; the measured number lies below the stated range.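

Going by these compounds alone, with 1H-pyrazol-4-yl on this aromatic carbon, ortho to a fused ring and meta to a fused ring, the read-out in this assay shows an at least 31-fold lower number from compound 2 to compound 4 (1.49 log units; beyond the scatter), and compound 4 is the only one of the four compounds with a value that is a number. This position can therefore carry a change that brings a measurable effect. The true size of the step cannot be read, because compound 2 sits at a limit of the assay: the limit of > 10000 nM in this assay, at which 3 of the 4 values shown sit.

As far as these compounds go, with a single group at this carbon, it stays open whether the effect belongs to 1H-pyrazol-4-yl itself. A phenyl ring or a methyl group in the same place would separate the two cases.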